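Adding an azetidinyloxy group to the most potent triazole analogue

A few compounds are considered here, and "the series" means these few. Any claim that something is new, unique, unknown or untested is made for them only; others in the source may bear on it.

Measured so far:
Compound 1, `C[C@@H]1CN(c2sc(C(F)(F)F)nc2-c2nc3ccccc3[nH]2)CCN1C(=O)Cn1ccc(C(=O)O)n1`, gives 2100 nM.
Compound 2, `C[C@@H]1CN(c2sc(C(F)(F)F)nc2-c2nc3ccccc3[nH]2)CCN1C(=O)Cn1cccn1`, gives 13 nM.
Compound 3, `Cc1nc(C)n(CC(=O)N2CCN(c3sc(C(F)(F)F)nc3-c3nc4ccccc4[nH]3)C[C@H]2C)n1`, gives 3.2 nM.

These three compounds share one core and differ only in the small ring carried on the chain attached to the carbonyl. They were tested in a functional assay on CHO-K1 cells for antagonist activity at C-X-C chemokine receptor type 3 (Homo sapiens), read by FLIPR, with a stated time of 10 min, in the presence of a further agent that is not named here; on this read-out lower numbers stand for stronger inhibition and higher numbers for weaker inhibition. Compound 3 stands lowest of the three numbers: it sits a 4.1-fold lower number from compound 2 to compound 3 (0.61 log units; beyond the scatter), and a 660-fold lower number from compound 1 to compound 3 (2.82 log units; beyond the scatter). The move from the carboxy-bearing ring to the plain ring is itself a 160-fold lower number from compound 1 to compound 2 (2.21 log units; beyond the scatter).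

Compound 4, `Cc1nc(C)n(CC(=O)N2CCN(c3sc(C(F)(F)F)nc3-c3nc4ccc(OC5CNC5)cc4[nH]3)C[C@H]2C)n1`, keeps everything in compound 3 and changes only the fused aromatic part: (azetidin-3-yl)oxy in place of hydrogen on an aromatic carbon. For the measured compounds named here, none of the measured steps touches this position; all three concern the ring on the chain. Going by the values given here, there is therefore no measured step that bears directly on the change, and the expectation is that the number stays close to that of compound 3, with no step beyond the scatter. The estimate for compound 4 in this assay is 5 nM, within 1.5 nM to 20 nM, which means an expected step of a 1.6-fold higher number from compound 3 to compound 4 (0.19 log units; within the scatter).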

Compound 4, half-maximal inhibitory concentration: 3.8 nM
For compound 4 the middle estimate is 1.3-fold (0.12 log units) above the measured one; measured number inside the range.
By their numbers in this assay, from the lowest: compounds 3 and 4 (each within the scatter of the next); then compound 2; then compound 1.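

In this assay, the step is a 1.2-fold higher number from compound 3 to compound 4 (0.07 log units; within the scatter), so this aromatic carbon of the fused system carries (azetidin-3-yl)oxy, with its 5 heavy atoms and four-membered ring, and the two numbers cannot be told apart. The earlier compounds shown here varied only the small ring on the chain, where a single change could be as large as a 660-fold lower number from compound 1 to compound 3 (2.82 log units; beyond the scatter), and they gave no information about the fused part. Nothing available explains why the numbers match here.

The compounds shown leave open whether a methoxy group, a carboxylic acid or a longer chain ending in an amine would give a similar number on this same carbon. They also leave open whether (azetidin-3-yl)oxy would have so little effect with the 1H-pyrazol-1-yl ring of compound 2 on the chain.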